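Thiourea aryl ethers: cytotoxicity notes toward compound 3

The source may hold more compounds than are shown below. What is called first, only, known or untested is meant among the compounds shown, and "the series" means these compounds.

Measured so far in an ADME assay on Ava5 cells (Homo sapiens) for cytotoxicity; a higher number here means that more compound is tolerated, a lower number that less compound is tolerated: compound 1 `NC(=S)Nc1cccc(OCCCCCCc2ccccc2)c1` gives 28000 nM; compound 2 `NC(=S)Nc1cccc(OCCCCCOc2ccc(Cl)cc2)c1` gives 7000 nM.

In this assay compound 2 stands lowest of the two numbers, with compound 1 the nearest by the step of a 4.0-fold lower number from compound 1 to compound 2 (0.60 log units; beyond the scatter). Compound 3 `CCN(CC)c1ccc(OCCCCCOc2cccc(NC(N)=S)c2)cc1` differs from compound 2 by diethylamino in place of chloro on an aromatic carbon, the new group sitting on an aromatic carbon of a six-membered aromatic ring of carbon only, para to a large group. Among the measured compounds shown here, the single measured step, a 4.0-fold lower number from compound 1 to compound 2 (0.60 log units; beyond the scatter), concerns the other end of the chain and gives no direct guide to a chloro-for-diethylamino exchange. No step beyond the scatter is therefore expected, estimated as no change at the digits printed from compound 2 to compound 3 (within the scatter). For compound 3 the expected value is 7000 nM, within 2500 nM to 20000 nM.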

Compound 3, half-maximal cytotoxic concentration: > 50000 nM
Compound 3 was reported as a limit; the forecaster's own chance of this, stated with the estimate: 15%; middle value at least 7.1-fold (0.85 log units) from the limit.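

In this assay, among the compounds shown here, diethylamino in place of chloro, para to a large group, gives an at least 7.1-fold higher number from compound 2 to compound 3 (0.85 log units; beyond the scatter), so a change at this position moves the read-out beyond the scatter, which the earlier compounds did not show. The result for compound 3 is a limit and not a number: the limit of > 50000 nM in this assay, at which 1 of the 3 values shown sits.

From the compounds shown here alone, whether a smaller amine such as dimethylamino or a carboxylic acid at this position would give a similar step stays open. Also open, going by these compounds, is whether the step would hold with a longer chain.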